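Dropping One Chloro From Compound 2

The compounds below may be only part of what the source reports. "The series", "measured", "known", "first", "only" and "open" are said of these compounds alone.

Compound 1 `N#Cc1ccc(Cn2cc(COc3ccc4c(=O)ccoc4c3)nn2)cc1` gives > 100000 nM in a functional assay on SGC-7901 cells (Homo sapiens) for cytotoxicity, read by MTT assay, with a stated time of 48 h; a higher number here means a weaker inhibitor, a lower number a stronger inhibitor; this value is a limit of the assay, not a number.
Compound 2 `O=c1ccoc2cc(OCc3cn(Cc4ccc(Cl)cc4Cl)nn3)ccc12` gives > 100000 nM in this assay; this too is a limit of the assay, not a number.

Among the compounds with values here, compound 2 therefore stands at the top end of what the assay can report, and it shares this position with the only other measured compound, since both sit at the limit of > 100000 nM in this assay, at which 2 of the 2 values shown sit. Within the data shown here, the one measured step, a step that the two limits leave unreadable from compound 1 to compound 2, changes the whole aryl group on the saturated chain carbon bound to an aromatic nitrogen, and its size cannot be read from two limits.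

Compound 3 `O=c1ccoc2cc(OCc3cn(Cc4ccc(Cl)cc4)nn3)ccc12` differs from compound 2 by hydrogen in place of chloro on an aromatic carbon. No measured step touches a single chloro in this way, so nothing shown gives a direction or a size for the change. With both measured compounds at the limit, compound 3 is expected to stay near the same region, so the step that the limit leaves unreadable from compound 2 to compound 3 is expected to be small and most likely unreadable. Compound 3 is estimated at 150000 nM, with a range from 40000 nM to 500000 nM.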

Compound 3, half-maximal inhibitory concentration: > 100000 nM
Compound 3 gave a limit, no number; the forecaster's own chance of this, stated with the estimate: 80%; the middle value is on the limit's open side.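

In this assay compound 3 gives > 100000 nM, which is a limit and not a number. Compound 1 and compound 2 are limits too, so no step among the three can be read: the limit of > 100000 nM in this assay, at which 3 of the 3 values shown sit.

The compounds shown leave open whether any change to the benzyl group would give a measurable value in this assay.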